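A few compounds are considered here, and "the series" means these few. Any claim that something is new, unique, unknown or untested is made for them only; others in the source may bear on it.

Working notes on the naphthyl-urea hydrazone series.

Two compounds have numbers in a functional assay on the whole organism (strain Swiss albino) with Mus musculus as the target, with a stated time of 0.5 h; a higher number here means that more compound is needed for the effect, a lower number that less compound is needed. Compound 1 `O=C(N/N=C/c1ccc(F)cc1)Nc1cccc2ccccc12` gives 300 mg/kg in this assay. Compound 2 `COc1ccc(/C=N/NC(=O)Nc2cccc3ccccc23)cc1OC` gives 100 mg/kg in this assay. Among the measured compounds shown here, compound 2 stands at the lower of the two numbers; the only neighbour, compound 1, shows a higher number, and the gap between them lies beyond the usual scatter. For the measured compounds named here, no pair of measured compounds differs in a single place, so no computed step is available.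

Compound 3 `COc1cccc(/C=N/NC(=O)Nc2cccc3ccccc23)c1` is the next one to be measured in this assay. Against compound 2 it differs as follows: hydrogen in place of methoxy on an aromatic carbon. The change sits on an aromatic carbon of a six-membered aromatic ring of carbon only, ortho to a methoxy group and para to a large group.

Going by the values given here, with only one methoxy group remaining, a modest rise in the number is expected, since compound 1, which carries no methoxy group, gives 300 mg/kg in this assay. The expected step from compound 2 to compound 3 is a 2.0-fold higher number from compound 2 to compound 3 (0.30 log units; within the scatter), a change roughly at the edge of the scatter. For compound 3 the estimated value in this assay is 200 mg/kg, with a range of 100 mg/kg to 300 mg/kg.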

Compound 3, minimum effective dose: 100 mg/kg
The estimate for compound 3 lay 2.0-fold (0.30 log units) above the measured number, and the stated range covers the measured number.
By their numbers in this assay, from the lowest: compounds 2 and 3 (each within the scatter of the next); then compound 1.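

In this assay, hydrogen in place of the methoxy group ortho to a methoxy group and para to a large group gives no change at the digits printed from compound 2 to compound 3 (within the scatter), so compound 3 keeps the number of compound 2 with this methoxy group gone. Among the compounds shown here, the other new step, 3-methoxyphenyl in place of 4-fluorophenyl on a carbon with a double bond to nitrogen, gives a 3.0-fold lower number from compound 1 to compound 3 (0.48 log units; beyond the scatter), and it is the only step that lies beyond the scatter; it places a measurable difference at this aromatic group, although it cannot separate the loss of the fluorine from the gain of the methoxy group. Nothing among the data shown explains the size of either step.

Open, on these data alone, is whether the remaining methoxy group in compound 3 contributes at all, a question that an unsubstituted phenyl group at this place would answer directly. Also open, as far as these compounds go, is how a hydroxyl group, a chlorine atom or a dimethylamino group at the same aromatic carbon would compare with the methoxy group of compound 2 in this whole-organism read-out.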